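Dropping one methoxy from compound 2

The source may hold more compounds than are shown below. What is called first, only, known or untested is meant among the compounds shown, and "the series" means these compounds.

Of the compounds shown here, two carry numbers so far. Compound 1 `COc1cc(/C=C2\CCC/C(=C\c3ccc([N+](=O)[O-])cc3)C2=O)ccc1O` gives in a functional assay on HSC-2 cells (Homo sapiens) for cytotoxicity (on this read-out lower numbers stand for higher toxicity in this test and higher numbers for lower toxicity in this test), a value of 2800 nM. Compound 2 `COc1cc(/C=C2\Cc3ccccc3/C(=C\c3ccc([N+](=O)[O-])cc3)C2=O)cc(OC)c1OC` gives in this assay a value of 550 nM, the lowest of the two numbers; compound 1 sits above it by a gap beyond the usual scatter. Going by the values given here, no pair of measured compounds differs in only one place, so no single step is settled yet.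

Compound 3 `COc1ccc(/C=C2\Cc3ccccc3/C(=C\c3ccc([N+](=O)[O-])cc3)C2=O)cc1OC` is the next entry. From compound 2 it differs by hydrogen in place of methoxy on an aromatic carbon; in words, hydrogen in place of methoxy on an aromatic carbon. Among the compounds with values here, no measured step of this kind exists, so the size of the change is open. A move of modest size is expected, not clearly beyond the scatter, with a slight lean toward a higher number. The step of a 1.5-fold higher number from compound 2 to compound 3 (0.16 log units; within the scatter) is expected to stay small. Compound 3 is expected to give about 800 nM, within a range from 350 nM to 2000 nM.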

Compound 3, half-maximal cytotoxic concentration: 920 nM
For compound 3 the middle estimate is 1.2-fold (0.06 log units) below the measured one, within the range that was stated.
By their numbers in this assay, from the lowest: compounds 2 and 3 (each within the scatter of the next); then compound 1.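

In this assay, going by these compounds alone, the first single-place step is now on record: hydrogen in place of methoxy on an aromatic carbon, ortho to a methoxy group and meta to a large group, gives a 1.7-fold higher number from compound 2 to compound 3 (0.22 log units; within the scatter) and stays within the scatter. Compound 2 and compound 3 therefore cannot be told apart on this read-out, and this one methoxy is not needed to keep the number in that range. No independent measurement bears on the reason for this result.

From the compounds shown here alone, whether this carbon accepts other substituents stays open, for example fluorine, a dimethylamino group or a longer alkoxy chain in place of the methoxy. Also open, going by these compounds, is whether the other two methoxy groups of compound 2 can be exchanged for hydrogen with an equally small step.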